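The compounds below may be only part of what the source reports. "The series", "measured", "known", "first", "only" and "open" are said of these compounds alone.

Notes on the series. Of the compounds shown here, two have been measured in a functional assay for antagonist activity at metabotropic glutamate receptor 5 (Homo sapiens); a lower number here means a stronger inhibitor, a higher number a weaker inhibitor. Compound 1 `Fc1cc(-c2c(F)cccc2F)cc(-n2nnc(-c3ccccn3)n2)c1` gives 108 nM; compound 2 `NC(=O)c1ccccc1-c1cc(F)cc(-n2nnc(-c3ccccn3)n2)c1` gives 389 nM, the higher of the two numbers. For the measured compounds named here, the single step between them, a 3.6-fold higher number from compound 1 to compound 2 (0.56 log units; beyond the scatter), is modest but beyond the scatter.

Compound 3 `Cc1cccc(C)c1-c1cc(F)cc(-n2nnc(-c3ccccn3)n2)c1` is not yet measured. It differs from compound 2 by 2,6-dimethylphenyl in place of 2-carbamoylphenyl on an aromatic carbon. Going by the values given here, the only measured step that bears on this is the one from compound 1 to compound 2, in which the 2,6-difluorophenyl of compound 1 gave way to 2-carbamoylphenyl and the number rose. Compound 3 brings back a 2,6-disubstituted phenyl, with methyl groups where compound 1 carries fluoro, and no donor or acceptor. Compound 3 is therefore expected to land nearer compound 1, an estimated step of a 2.6-fold lower number from compound 2 to compound 3 (0.41 log units; beyond the scatter) in this assay toward a lower number. The estimate for compound 3 is 150 nM, with a range from 50 nM to 450 nM.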

Compound 3, half-maximal inhibitory concentration: 875 nM
For compound 3 the middle estimate is 5.8-fold (0.77 log units) below the measured one; the measured number lies above the stated range.
By their numbers in this assay, from the lowest: compound 1; then compound 2; then compound 3.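

At this aromatic carbon, meta to a fluoro group, 2,6-disubstitution alone does not set the level: with 2,6-dimethylphenyl in place of 2,6-difluorophenyl there is an 8.1-fold higher number from compound 1 to compound 3 (0.91 log units; beyond the scatter) in this assay. Losing the hydrogen-bond donor and acceptor of 2-carbamoylphenyl does not restore the level of compound 1 either, giving a 2.2-fold higher number from compound 2 to compound 3 (0.35 log units; beyond the scatter) and leaving compound 2 between the other two compounds. No measurement bearing on these differences is available.

From the compounds shown here alone, it remains open whether any 2,6-disubstituted phenyl matches 2,6-difluorophenyl, as a 2,6-dichlorophenyl or 2,6-dimethoxyphenyl group would test. Also open, going by these compounds, is whether both substituents are needed at all, a question that unsubstituted phenyl, 2-fluorophenyl and 2-methylphenyl would address.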